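Nitro-thiazinone series: tolerance on Vero cells, fluorobenzyl variants

This account rests on a few compounds, and the source may have more. Where it says the series, first, only, none or still open, it means among the compounds named here.

Measured so far:
compound 1 `CON=C1CCC(N(C)N2CCN(c3nc(=O)c4cc(C(F)(F)F)cc([N+](=O)[O-])c4s3)CC2)CC1`: > 64 ug/mL
compound 2 `O=c1nc(N2CCN(NCc3ccc(F)cc3)CC2)sc2c([N+](=O)[O-])cc(C(F)(F)F)cc12`: > 64 ug/mL

In an ADME assay on Vero cells (Chlorocebus sabaeus) for cytotoxicity, read by MTT assay, with a stated time of 72 h (a higher number here means that more compound is tolerated, a lower number that less compound is tolerated), compound 1 reaches only a limit, > 64 ug/mL. Compound 2 likewise reaches only a limit in this assay, > 64 ug/mL. The step that the two limits leave unreadable from compound 1 to compound 2 therefore cannot be read in size or direction. Among the compounds with values here, compound 2 thus stands at the ceiling of what this assay reports; both values so far sit there, see (the limit of > 64 ug/mL in this assay, at which 2 of the 2 values shown sit).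

Compound 3 `O=c1nc(N2CCN(NCc3cc(F)cc(F)c3)CC2)sc2c([N+](=O)[O-])cc(C(F)(F)F)cc12` differs from compound 2 by 3,5-difluorophenyl in place of 4-fluorophenyl on a saturated chain carbon bound to an amine nitrogen. Within the data shown here, no measured step touches this part of the molecule, so the only guide is that both measured compounds sit at the limit. The step of a number no higher from compound 2 to compound 3 (the limit leaves the size open) is expected to be none beyond the scatter. Compound 3 is estimated at 64 ug/mL, with a range from 32 ug/mL to 128 ug/mL, most likely again reported only as a limit.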

Compound 3, half-maximal cytotoxic concentration: > 64 ug/mL
Compound 3: only a limit was reported; the forecaster's own chance of this, stated with the estimate: 80%; the middle value lies on the limit itself.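

In this assay compound 3 also reaches only a limit, so no step among compound 1, compound 2 and compound 3 can be read: the limit of > 64 ug/mL in this assay, at which 3 of the 3 values shown sit.

The compounds shown leave open whether these three differ in tolerance at all, and which change to the benzyl group, if any, would give a readable value.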